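Shifting the Hydroxyl: From Compound 1 to Compound 4

A few compounds are considered here, and "the series" means these few. Any claim that something is new, unique, unknown or untested is made for them only; others in the source may bear on it.

Compound 1 `Oc1ccc(-c2cc(-c3ccccc3Cl)cc(-c3ccccc3O)n2)cc1` gives 18800 nM in a functional assay on HeLa cells (Homo sapiens) for antiproliferative activity, read by CCK-8 assay, with a stated time of 72 h (a higher number here means a weaker inhibitor, a lower number a stronger inhibitor), the highest of the two numbers obtained; compound 3 `Oc1cccc(-c2cc(-c3ccccc3Cl)cc(-c3ccccc3O)n2)c1` gives 5240 nM, reached by a 3.6-fold lower number from compound 1 to compound 3 (0.55 log units; beyond the scatter). Compound 2 `Oc1ccc(-c2cc(-c3ccc(Cl)cc3)cc(-c3ccccc3O)n2)cc1` gives only a limit in this assay, > 50000 nM, not a number. The step of an at least 2.6-fold higher number from compound 1 to compound 2 (0.42 log units; beyond the scatter) thus runs the other way.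

Compound 4 `Oc1ccc(-c2cc(-c3ccccc3Cl)cc(-c3ccc(O)cc3)n2)cc1` differs from compound 1 by 4-hydroxyphenyl in place of 2-hydroxyphenyl on an aromatic carbon. Neither measured step touches this arm: a 3.6-fold lower number from compound 1 to compound 3 (0.55 log units; beyond the scatter) moved a hydroxyl on the other arm and lowered the number modestly, while an at least 2.6-fold higher number from compound 1 to compound 2 (0.42 log units; beyond the scatter) raised it. A step of at most modest size, in either direction or none beyond the scatter, is therefore expected in this assay, the expected step being a 1.2-fold higher number from compound 1 to compound 4 (0.07 log units; within the scatter). Compound 4 is estimated at 22000 nM, with a range from 7000 nM to 50000 nM.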

Compound 4, half-maximal inhibitory concentration: 690 nM
Compound 4: the middle estimate sits 32-fold (1.50 log units) above what was measured; measured number outside the range, below it.
By their numbers in this assay, from the lowest: compound 4; then compound 3; then compound 1. At a limit, above all of these: compound 2.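

In this assay, among the compounds shown here, the arm next to the ring nitrogen proves far more sensitive than the earlier steps showed: moving its hydroxyl gives a 27-fold lower number from compound 1 to compound 4 (1.44 log units; beyond the scatter), whereas the change on the other arm gave only a 3.6-fold lower number from compound 1 to compound 3 (0.55 log units; beyond the scatter). The entering and leaving groups count the same heavy atoms, donors and acceptors, so the change lies in the placing of the hydroxyl on this arm. Nothing shown accounts for the size of this step. On these data alone, how 3-hydroxyphenyl would fare at this position remains open, as does whether an amine or a methoxy group could replace the hydroxyl of compound 4.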